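Cyclopentyl replaces difluoropropyl on the carbonyl carbon

This account rests on a few compounds, and the source may have more. Where it says the series, first, only, none or still open, it means among the compounds named here.

Of the compounds shown here, three sharing one core have been measured in a functional assay on isolated protein for inhibition of Glucose-dependent insulinotropic receptor (Homo sapiens), read by HTRF and cAMP accumulation; on this read-out higher numbers stand for an effect only at larger amounts of compound and lower numbers for an effect already at smaller amounts. Compound 1 `Cc1nc(S(C)(=O)=O)ccc1Oc1ncnc(OC2CCN(C(=O)SC3CC3)CC2)c1F` gives 24.9 nM. Compound 2 `Cc1nc(S(C)(=O)=O)ccc1Oc1ncnc(OC2CCN(C(=O)C(F)(F)F)CC2)c1F` gives 151 nM, and compound 3 `CCC(F)(F)C(=O)N1CCC(Oc2ncnc(Oc3ccc(S(C)(=O)=O)nc3C)c2F)CC1` gives 17.4 nM, the lowest of the three numbers, though a 1.4-fold lower number from compound 1 to compound 3 (0.16 log units; within the scatter) lies within the scatter while an 8.7-fold lower number from compound 2 to compound 3 (0.94 log units; beyond the scatter) and a 6.1-fold higher number from compound 1 to compound 2 (0.78 log units; beyond the scatter) lie beyond it. Compound 4 `Cc1nc(S(C)(=O)=O)ccc1Oc1ncnc(OC2CCN(C(=O)C3CCCC3)CC2)c1F` carries cyclopentyl in place of 1,1-difluoropropyl on a carbonyl carbon. The measured steps bearing on this position all exchange the group on that carbonyl carbon: a 6.1-fold higher number from compound 1 to compound 2 (0.78 log units; beyond the scatter) was modest, whereas a 1.4-fold lower number from compound 1 to compound 3 (0.16 log units; within the scatter) was small. Since a 1.4-fold lower number from compound 1 to compound 3 (0.16 log units; within the scatter) stayed within the scatter, compound 4 is expected to show only a small step, a 2.0-fold higher number from compound 3 to compound 4 (0.30 log units; within the scatter), in this assay. Compound 4 is therefore estimated at 35 nM, within 10 nM to 130 nM.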

Compound 4, half-maximal effective concentration: 72.8 nM
Compound 4: the middle estimate sits 2.1-fold (0.32 log units) below what was measured, and the stated range covers the measured number.
By their numbers in this assay, from the lowest: compounds 3 and 1 (each within the scatter of the next); then compound 4; then compound 2.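

In this assay, the group on this carbonyl carbon matters even where the count of heavy atoms stays the same: a 4.2-fold higher number from compound 3 to compound 4 (0.62 log units; beyond the scatter) separates the ringed cyclopentyl from the open 1,1-difluoropropyl. Cyclopentyl also stands apart from the other two groups, with a 2.9-fold higher number from compound 1 to compound 4 (0.47 log units; beyond the scatter) on one side and a 2.1-fold lower number from compound 2 to compound 4 (0.32 log units; beyond the scatter) on the other. No supporting measurement bears on what lies behind these steps. As far as these compounds go, whether cyclobutyl, or a cyclopentyl carrying fluorine, would fall nearer compound 3 or compound 4 stays open.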